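Chloro to cyano on the sulfonyl aryl ring of two cores

The source may report more compounds than this note shows. Statements on the series, on what has been measured and on what is new or still open speak of the compounds shown alone.

Compound 2 `COc1ccc2ncc(S(=O)(=O)c3cccc(Cl)c3)c(N3CCC(C)CC3)c2c1` and compound 1 `COc1ccc2ncc(S(=O)(=O)c3cccc(C#N)c3)c(N3CCC(C)CC3)c2c1` share a core and differ by cyano in place of chloro on an aromatic carbon, the cyano standing meta to a large group. In an assay on isolated protein for displacement of a labelled ligand from metabotropic glutamate receptor 5 (Homo sapiens), with a stated time of 60 min, tested at 1 uM (a lower number here means less inhibition, a higher number more inhibition at the concentration tested (going by the name of the read-out)), compound 2 gives -3%, while compound 1 gives 90%, a step of a number 93 percentage points higher from compound 2 to compound 1 (beyond the scatter). Compound 3 `CC1CCN(c2c(S(=O)(=O)c3ccc(Cl)cc3)cnc3cc(F)ccc23)CC1` rests on a different core; the difference between the two cores is not broken down here. In this assay compound 3 gives 90%. Compound 4 `CC1CCN(c2c(S(=O)(=O)c3ccc(C#N)cc3)cnc3cc(F)ccc23)CC1` differs from compound 3 by cyano in place of chloro on an aromatic carbon, here para to a large group, so the same kind of change, not the same. Because compound 3 already stands at 90%, the step is expected to be far smaller than the earlier one, about a number 2 percentage points higher from compound 3 to compound 4 (within the scatter). Compound 4 is estimated at 92%, between 80% and 100%.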

Compound 4, a percentage reported as inhibition, at one concentration (the size of the read-out at that concentration, not a potency): 83%
Beside the measured number, compound 4's estimate is 9 percentage points above it; the range from low to high includes it.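

In this assay, the swap of chloro for cyano does not carry over from one core to the other: the same change on two cores in this assay, a number 93 percentage points higher (beyond the scatter) from compound 2 to compound 1 and a number 7 percentage points lower (within the scatter) from compound 3 to compound 4, 100 percentage points apart, beyond the scatter of two such steps

Going by these compounds alone, on the core of compound 3, the change from 4-chlorophenyl to 4-cyanophenyl gives a number 7 percentage points lower from compound 3 to compound 4 (within the scatter), so the large gain on the first core has no counterpart here. What this does not show is the source of the gap, since the two pairs differ both in their cores and in where the group sits on the aryl ring, and one reading at a single concentration gives no potency.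

On these data alone, it remains open how the swap behaves with the group at the same place on both cores. Also open, as far as these compounds go, is how an amine or a carboxylic acid on that ring would read.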